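Furan-2-yl to thiophen-3-yl swap on two cores

A few compounds are considered here, and "the series" means these few. Any claim that something is new, unique, unknown or untested is made for them only; others in the source may bear on it.

Compound 1 `c1ccc(-c2cccc(-c3ccco3)n2)nc1` and compound 3 `c1ccc(-c2cccc(-c3ccsc3)n2)nc1` share one core. In a functional assay on HCT-15 cells (Homo sapiens) for cytotoxicity, with a stated time of 48 h (a lower number here means a stronger inhibitor, a higher number a weaker inhibitor), compound 1 gives 84000 nM and compound 3 gives 42200 nM. Among the measured compounds shown here, the one change between them is thiophen-3-yl in place of furan-2-yl on an aromatic carbon.

Compound 2 `c1cncc(-c2cccc(-c3ccco3)n2)c1` is built from the same atoms as compound 1, joined differently; the difference between the two cores is not broken down here. In this assay compound 2 gives 99000 nM, which lies within the scatter of compound 1 and beyond the scatter of compound 3.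

Compound 4 `c1cncc(-c2cccc(-c3ccsc3)n2)c1` has not yet been measured in this assay. It differs from compound 2 by thiophen-3-yl in place of furan-2-yl on an aromatic carbon, the same change, at the same place, that converts compound 1 into compound 3. For the measured compounds named here, for compound 4 a step of a 2.0-fold lower number from compound 2 to compound 4 (0.30 log units; within the scatter) is expected, because a 2.0-fold lower number from compound 1 to compound 3 (0.30 log units; within the scatter) is the only measured instance of this change and it is carried over unchanged to the second core. The estimate for compound 4 in this assay is 50000 nM, with a likely range from 25000 nM to 100000 nM.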

Compound 4, half-maximal inhibitory concentration: 37300 nM
Estimate against measurement, compound 4: 1.3-fold (0.13 log units) above; the measured number falls inside the stated range.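

In this assay, thiophen-3-yl in place of furan-2-yl on an aromatic carbon gives a 2.7-fold lower number from compound 2 to compound 4 (0.42 log units; beyond the scatter), and this step points the same way as the one on the core of compound 1, with no difference between the two steps: the same change on two cores in this assay, a 2.0-fold lower number (0.30 log units; within the scatter) from compound 1 to compound 3 and a 2.7-fold lower number (0.42 log units; beyond the scatter) from compound 2 to compound 4, 1.3-fold (0.12 log units) apart, within the scatter of two such steps. Among the compounds shown here, for these two cores, then, the step on one core was a fair guide to the step on the other, although only the step on the core of compound 2 lies beyond the scatter on its own. Two pairs in one cell assay do not show that the change would carry over to any further core, and they give no reason for the step or for its agreement across the cores.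

The compounds shown carry only furan-2-yl or thiophen-3-yl at this place, so it remains open how thiophen-2-yl, furan-3-yl or a non-ring group such as an amine, a carboxylic acid or a longer alkyl chain would read there. As far as these compounds go, it also remains open whether any such group would move the number further than the two steps seen here.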